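This account rests on a few compounds, and the source may have more. Where it says the series, first, only, none or still open, it means among the compounds named here.

Measured so far:
- compound 1, `CCCOC(=O)c1cccc(C(=O)Nc2cccc(-c3cc(C(=O)Nc4ccncc4F)ccc3CN)c2)c1`: 1.8 nM
- compound 2, `NCc1ccc(C(=O)Nc2ccncc2F)cc1-c1cccc(C(=O)Nc2cccc(CC(=O)O)c2)c1`: 1.5 nM

Both compounds were run in an assay on cells for inhibition of Rho-associated protein kinase 2 (Homo sapiens), read by radiometric assay and 33P incorporation, in the presence of a further agent that is not named here; on this read-out higher numbers stand for weaker inhibition and lower numbers for stronger inhibition. Compound 1 gives 1.8 nM and compound 2 gives 1.5 nM. Compound 2 holds the lowest of the two numbers, but the gap to compound 1 is within the scatter, so the two are not separated by this read-out.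

Compound 3, `CC(C)OC(=O)c1cccc(NC(=O)c2cccc(-c3cc(C(=O)Nc4ccncc4F)ccc3CN)c2)c1`, has not been measured. It differs from compound 2 in one place: isopropoxycarbonyl in place of carboxymethyl on an aromatic carbon. Apart from that, the shared core and the rest of the molecule are unchanged.

For the measured compounds named here, no step between measured compounds bears on this change directly. The nearest point of comparison is compound 1, which carries a related ester at the same position and gives 1.8 nM; since that value sits within the scatter of compound 2, a step of about a 1.3-fold higher number from compound 2 to compound 3 (0.12 log units; within the scatter) is expected, with no direction beyond the scatter. Compound 3 is estimated at 2 nM in this assay, with a range of 0.8 nM to 5 nM.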

Compound 3, half-maximal inhibitory concentration: 7 nM
Beside the measured number, compound 3's estimate is 3.5-fold (0.54 log units) below it; measured number above the stated range.
By their numbers in this assay, from the lowest: compounds 2 and 1 (each within the scatter of the next); then compound 3.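

In this assay, for the compounds shown here, the change from carboxymethyl to isopropoxycarbonyl on an aromatic carbon, meta to a large group, gives the first readable step at this position: a 4.7-fold higher number from compound 2 to compound 3 (0.67 log units; beyond the scatter). The position is therefore not indifferent to the group it carries, although the size of the step is modest and compound 3 still gives 7 nM. Nothing in the available data accounts for this step.

The step combines several differences: the group grows from 4 to 6 heavy atoms, its hydrogen-bond donors go from 1 to 0, and its hydrogen-bond acceptors go from 1 to 2, so these two compounds cannot show which difference goes with the higher number. As far as these compounds go, it remains open whether a carboxylic acid directly on the aromatic carbon, a methoxycarbonyl group, an aminomethyl group or a longer chain ending in a carboxylic acid would read nearer to compound 2 or to compound 3 in this assay.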